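Para-Dimethylamino on the Benzamide of a Weak Pyrimidine Series

The source may hold more compounds than are shown below. What is called first, only, known or untested is meant among the compounds shown, and "the series" means these compounds.

Measured compounds:
- compound 1, `O=C(Nc1cccc(Nc2ncc(F)c(Nc3ccc(F)cc3)n2)c1)c1ccccc1`: > 10000 nM
- compound 2, `O=C(Nc1ccccn1)c1cccc(Nc2ncc(F)c(Nc3ccc(F)cc3)n2)c1`: 13700 nM
- compound 3, `O=C(Nc1nccs1)c1cccc(Nc2ncc(F)c(Nc3ccc(F)cc3)n2)c1`: > 10000 nM

All three share one core and differ only in the amide attached to it. In a functional assay on KBVIN cells (Homo sapiens) for antiproliferative activity, read by sulforhodamine B assay, with a stated time of 3 days (a lower number here means a stronger inhibitor of growth, a higher number a weaker inhibitor of growth), compound 1 reaches only a limit of the assay, > 10000 nM, not a number. Compound 2 gives a number, 13700 nM. Compound 3 again stops at a limit, > 10000 nM. Because of the limit of > 10000 nM in this assay, at which 2 of the 3 values shown sit, none of the steps among these three can be sized: a step that the limit leaves unreadable from compound 1 to compound 2, a step that the two limits leave unreadable from compound 1 to compound 3 and a step that the limit leaves unreadable from compound 2 to compound 3 all stay unreadable. What the data do show is that every measured member of this set is a weak inhibitor of growth.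

Compound 4, `CN(C)c1ccc(C(=O)Nc2cccc(Nc3ncc(F)c(Nc4ccc(F)cc4)n3)c2)cc1`, comes from compound 1 through (dimethylamino in place of hydrogen on an aromatic carbon). For the measured compounds named here, no measured step changes this part of the structure, so nothing here indicates how large a shift to expect; the only guide is that compound 1 and its two relatives all sit at or near the limit. Compound 4 is therefore expected to remain a weak inhibitor, with the estimated step that the limit leaves unreadable from compound 1 to compound 4 lying within the scatter. Compound 4 is estimated at 12000 nM, between 4000 nM and 40000 nM.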

Compound 4, concentration for 50% growth inhibition: > 10000 nM
Compound 4 ended at the assay's limit (the forecaster's own chance of this, stated with the estimate: 60%); the middle value is on the limit's open side.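

Compound 1 and compound 4 both stop at a limit of this assay rather than a number, so no size can be read for the change between them: the limit of > 10000 nM in this assay, at which 3 of the 4 values shown sit.

The compounds shown leave open whether dimethylamino in place of hydrogen changes growth inhibition at all, and what change on the shared core would give a strong inhibitor of growth.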